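A few compounds are considered here, and "the series" means these few. Any claim that something is new, unique, unknown or untested is made for them only; others in the source may bear on it.

Compound 1, `CCc1cc2ccccc2n(Cc2nc3ccccc3n2CCCCF)c1=O`, is followed here by compound 4, `O=c1c(Br)cc2ccccc2n1Cc1nc2ccccc2n1CCCCF`, which is not yet measured. Of the numbers at hand, compound 1 gives 85100 nM in an ADME assay on HEp-2 cells (Homo sapiens) for cytotoxicity (a lower number here means that less compound is tolerated, a higher number that more compound is tolerated), the lowest of the two numbers reported. Compound 3, `CN(C)CCn1c(CN2C(=O)CCc3ccccc32)nc2ccccc21`, gives 153000 nM in this assay, which lies within the scatter of compound 1. Compound 2, `N#CCCCCn1c(CN2C(=O)CS(=O)(=O)c3ccccc32)nc2ccccc21`, reaches only a limit of the assay, > 270000 nM, and this is noted as the limit of > 270000 nM in this assay, at which 1 of the 3 values shown sits. Among the compounds with values here, no step between two measured compounds that differ in a single place is available, so the change from compound 1 to compound 4 has no measured counterpart. That change is bromo in place of ethyl on an aromatic carbon. With nothing measured for such a swap, a step of no more than the scatter in this assay is expected, in either direction. For compound 4 a value of 90000 nM is estimated, between 35000 nM and 250000 nM, which corresponds to an expected step of a 1.1-fold higher number from compound 1 to compound 4 (0.02 log units; within the scatter).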

Compound 4, half-maximal cytotoxic concentration: 26200 nM
Estimate against measurement, compound 4: 3.4-fold (0.54 log units) above; measured number outside the range, below it.
By their numbers in this assay, from the lowest: compound 4; then compounds 1 and 3 (each within the scatter of the next). At a limit, above all of these: compound 2.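

In this assay, bromo in place of ethyl on an aromatic carbon gives a 3.2-fold lower number from compound 1 to compound 4 (0.51 log units; beyond the scatter), the only change in one place among the compounds shown. Within the data shown here, it shows that this carbon, two atoms from the ring nitrogen, is a place where a single swap on the core of compound 1 can move the number beyond the scatter, which the earlier compounds could not show because they differ from one another in more than one place. Nothing at hand accounts for the size or direction of this step.

From the compounds shown here alone, whether chloro, methoxy, an amine or a carboxylic acid on this carbon would move the number the same way remains open. Also open, going by these compounds, is whether the swap would give a similar step with an amine or a nitrile in the chain of compound 1.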